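The compounds below may be only part of what the source reports. "The series", "measured", "known", "first", "only" and "open" are said of these compounds alone.

Working notes on the series. Compound 1 `Nc1scc(CN2CCN(c3cccnc3)CC2)c1C(=O)c1ccc(Cl)cc1` gives 3.2% in a functional assay on CHO cells with adenosine receptor A1 (Homo sapiens) as the target, read by cAMP accumulation and immunoassay, with a stated time of 6 min, tested at 0.01 uM; on this read-out lower numbers stand for a stronger effect and higher numbers for a weaker effect at the one concentration tested. Among the compounds with values here, compound 2 `Nc1scc(CN2CCN(c3cccc(F)c3F)CC2)c1C(=O)c1ccc(Cl)cc1` gives -13% in this assay, the lowest of the two numbers so far; the only measured step, a number 16.2 percentage points lower from compound 1 to compound 2 (beyond the scatter), is the one that leads to it. Compound 3 `Nc1scc(CN2CCN(c3ccc(F)c(Cl)c3)CC2)c1C(=O)c1ccc(Cl)cc1` differs from compound 2 by 3-chloro-4-fluorophenyl in place of 2,3-difluorophenyl on an amine nitrogen in a ring. Within the data shown here, no measured step swaps one halogenated phenyl for another, so the step from compound 1 to compound 2 bears only loosely on it; a step within the scatter, of either sign, is expected, namely a number 3 percentage points higher from compound 2 to compound 3 (within the scatter). Compound 3 is therefore estimated at -10%, between -30% and 10%.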

Compound 3, a percentage reported as activity, at one concentration (the size of the read-out at that concentration, not a potency): 4.2%
Compound 3: the middle estimate sits 14.2 percentage points below what was measured; measured number inside the range.
By their numbers in this assay, from the lowest: compound 2; then compounds 1 and 3 (each within the scatter of the next).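

In this assay, the position on the amine nitrogen in a ring proves sensitive to which halogenated phenyl sits there: one such group for another gives a number 17.2 percentage points higher from compound 2 to compound 3 (beyond the scatter). A halogenated phenyl in place of pyridin-3-yl does not by itself give the lower number: 3-chloro-4-fluorophenyl gives a number 1 percentage points higher from compound 1 to compound 3 (within the scatter). Nothing available explains the difference between these two groups. Going by these compounds, the two phenyls differ in both halogen and pattern, so which of these matters stays open. An unsubstituted phenyl or a 2,3-dichlorophenyl at this position would bear on that.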